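Chlorophenyl Sulfide Replaces Methylpiperazine on a Shared Core

The source may hold more compounds than are shown below. What is called first, only, known or untested is meant among the compounds shown, and "the series" means these compounds.

Three compounds share one core and one side chain and differ only in the group carried on an aromatic carbon of that core. Compound 1 `Cc1cc(-c2ccco2)cn2c(CSCCc3ccccc3)cnc12` bears a furan-2-yl group, and in an ADME assay on HEL cells (Homo sapiens) for cytotoxicity, with a stated time of 3 days (a lower number here means that less compound is tolerated, a higher number that more compound is tolerated), compound 1 gives 40 ug/mL. Compound 2 `Cc1cc(-n2cccc2)cn2c(CSCCc3ccccc3)cnc12` carries 1H-pyrrol-1-yl in its place, and in this assay compound 2 gives 11 ug/mL. That exchange produced a 3.6-fold lower number from compound 1 to compound 2 (0.56 log units; beyond the scatter). Compound 3 `Cc1cc(N2CCN(C)CC2)c2ncc(CSCCc3ccccc3)n2c1` carries a 4-methylpiperazin-1-yl group; in this assay compound 3 gives "not determined" (no result reported), so no number exists for it and it has no place on the scale set by the other two.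

Compound 4 `Cc1cc(Sc2ccc(Cl)cc2)c2ncc(CSCCc3ccccc3)n2c1` differs from compound 3 by (4-chlorophenyl)sulfanyl in place of 4-methylpiperazin-1-yl on an aromatic carbon. Among the measured compounds shown here, no measured step involves either of these groups; the single step on record, from compound 1 to compound 2, concerns a different pair of groups, so neither the direction nor the size of the change can be read from the measured compounds. The values of compound 1 and compound 2 only show the range in which this series has been observed. For compound 4 the expected value in this assay is 20 ug/mL, within an estimated range from 5 ug/mL to 70 ug/mL.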

Compound 4, half-maximal cytotoxic concentration: 100 ug/mL
Compound 4: the middle estimate sits 5.0-fold (0.70 log units) below what was measured, and the stated range ends below it.
By their numbers in this assay, from the lowest: compound 2; then compound 1; then compound 4.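

Compound 3 has no number in this assay, so although compound 4 gives 100 ug/mL there, no step can be read from compound 3 to compound 4. The compounds shown leave open how (4-chlorophenyl)sulfanyl compares with 4-methylpiperazin-1-yl on the shared core. Nothing on hand offers an explanation for the value of compound 4.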